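Dropping One Methoxy from a Dimethoxy Quinazoline-Type Core

The source may report more compounds than this note shows. Statements on the series, on what has been measured and on what is new or still open speak of the compounds shown alone.

Measured so far:
Compound 1, `Fc1ccc(Nc2ncnc3[nH]ccc23)cc1`: > 32000 nM
Compound 2, `Cc1[nH]c2ncnc(Oc3ccc(F)cc3F)c2c1C`: 2000 nM
Compound 3, `COc1cc2ncnc(Oc3ccc(F)cc3F)c2cc1OC`: 1200 nM

In an assay on HEK293-TREx cells for antagonist activity at transient receptor potential cation channel subfamily A member 1 (Homo sapiens), read by fluorescence and calcium flux, with a stated time of 72 h (a higher number here means a weaker inhibitor, a lower number a stronger inhibitor), compound 1 gives only a limit, > 32000 nM, and not a number; this is the limit described by the limit of > 32000 nM in this assay, at which 1 of the 3 values shown sits. Compound 2 gives 2000 nM in this assay. Compound 3 gives 1200 nM in this assay; its number and that of compound 2 lie within the usual scatter of each other, so the two cannot be told apart, and compound 3 is simply one of the two compounds for which a number, rather than a limit, was obtained.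

Compound 4, `COc1ccc2c(Oc3ccc(F)cc3F)ncnc2c1`, has not yet been measured. It differs from compound 3 in one place: hydrogen in place of methoxy on an aromatic carbon. Within the data shown here, no measured pair of compounds shows this change directly. Since compound 2, which carries no methoxy at all, gives 2000 nM, and compound 3 with two methoxy groups gives 1200 nM, removing one methoxy is expected to move the number little, if at all, beyond the scatter. The step from compound 3 to compound 4 is therefore estimated as a 1.5-fold higher number from compound 3 to compound 4 (0.18 log units; within the scatter), and compound 4 is expected to give about 1800 nM in this assay, within a range from 700 nM to 5000 nM.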

Compound 4, half-maximal inhibitory concentration: 3000 nM
Compound 4: the middle estimate sits 1.7-fold (0.22 log units) below what was measured, and the stated range covers the measured number.
By their numbers in this assay, from the lowest: compounds 3, 2 and 4 (each within the scatter of the next, the first and the last beyond it). At a limit, above all of these: compound 1.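

Among these compounds, this is the first direct reading of what a single methoxy contributes on this core. With hydrogen in its place, this assay shows a 2.5-fold higher number from compound 3 to compound 4 (0.40 log units; beyond the scatter), a modest step but one that can be told from the scatter. The methoxy at this place, on the carbon-only aromatic ring and ortho to the methoxy that stays, therefore counts for something in this assay, yet removing it costs only a small part of the inhibition and leaves a measurable number, and nothing shown gives a measured reason for this step.

The compounds shown leave open whether the effect belongs to this position alone, since the matching change at the methoxy that remains in compound 4 has no pair to read it from, and a core with neither methoxy is not among the compounds shown here. They also leave open whether a different group at the same place, such as an amine, a chlorine atom or a longer chain like ethoxy, would give a lower number than compound 3 or only match it.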